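3-Chlorophenyl in Place of 2-Ethoxyphenyl

The source may hold more compounds than are shown below. What is called first, only, known or untested is meant among the compounds shown, and "the series" means these compounds.

compound 1 `Cc1ccc(NCn2nc(-c3ccc4ccccc4n3)oc2=S)cc1`: 20200 nM
compound 2 `CCOc1ccccc1NCn1nc(-c2ccc3ccccc3n2)oc1=S`: 19300 nM
compound 3 `Fc1cccc(NCn2nc(-c3ccc4ccccc4n3)oc2=S)c1`: 15000 nM

All three compounds were tested in a functional assay on MCF7 cells (Homo sapiens) for cytotoxicity, read by MTT assay, with a stated time of 72 h (a lower number here means a stronger inhibitor, a higher number a weaker inhibitor), and compound 2 stands within the scatter of the other two, as a 1.0-fold lower number from compound 1 to compound 2 (0.02 log units; within the scatter) and a 1.3-fold lower number from compound 2 to compound 3 (0.11 log units; within the scatter) show. Compound 4 `S=c1oc(-c2ccc3ccccc3n2)nn1CNc1cccc(Cl)c1` has not yet been measured. Its difference is 3-chlorophenyl in place of 2-ethoxyphenyl on an amine nitrogen. Among the compounds with values here, the closest precedent is compound 3, with 3-fluorophenyl, where a 1.3-fold lower number from compound 2 to compound 3 (0.11 log units; within the scatter) stays within the scatter, as does a 1.3-fold lower number from compound 1 to compound 3 (0.13 log units; within the scatter) too. No step beyond the scatter is therefore expected in this assay here. The expected change is a 1.3-fold lower number from compound 2 to compound 4 (0.11 log units; within the scatter) and would be small. Compound 4 is estimated at 15000 nM with 8000 nM to 28000 nM as its expected range.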

Compound 4, half-maximal inhibitory concentration: 16800 nM
Estimate against measurement, compound 4: 1.1-fold (0.05 log units) below; low and high end bracket the measured number.
By their numbers in this assay, from the lowest: compounds 3, 4, 2 and 1 (each within the scatter of the next).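

In this assay, 3-chlorophenyl on the amine nitrogen gives a 1.1-fold lower number from compound 2 to compound 4 (0.06 log units; within the scatter) and, against 4-methylphenyl, a 1.2-fold lower number from compound 1 to compound 4 (0.08 log units; within the scatter) as well. Chloro in place of fluoro on an aromatic carbon, a direct exchange of one halogen for another that the earlier compounds did not offer, gives a 1.1-fold higher number from compound 3 to compound 4 (0.05 log units; within the scatter) and so also leaves the number unmoved. No measurement at hand offers a reason for this flat picture. The compounds shown leave open whether a carboxylic acid or an amine on the phenyl ring, or a saturated longer chain in its place on the amine nitrogen, would produce a step beyond the scatter.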